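Amino for hydroxy on the glycolamide chain, second core

The source may hold more compounds than are shown below. What is called first, only, known or untested is meant among the compounds shown, and "the series" means these compounds.

Compound 1 `COc1ccc(C(=O)c2ccc(OC)c3c2C=CC(C)(C)O3)c(NC(=O)CO)c1` and compound 2 `COc1ccc(C(=O)c2ccc(OC)c3c2C=CC(C)(C)O3)c(NC(=O)CN)c1` share one core; compound 3 `C=C(c1ccc2c(c1)C=CC(C)(C)O2)c1ccc(OC)cc1NC(=O)CO` and compound 4 `C=C(c1ccc2c(c1)C=CC(C)(C)O2)c1ccc(OC)cc1NC(=O)CN` share another. The difference between the two cores is not broken down here. In a functional assay on A549 cells (Homo sapiens) for antiproliferative activity, read by MTT assay, with a stated time of 48 h (a lower number here means a stronger inhibitor, a higher number a weaker inhibitor), compound 1 gives 100 nM, compound 2 gives 420 nM and compound 3 gives 40 nM. Compound 3 stands lowest of the three measured numbers, with compound 1 nearest and compound 2 furthest.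

Among the compounds with values here, the one counted change on the first core, (amino in place of hydroxy on a saturated chain carbon bound to a carbonyl carbon), produced a 4.2-fold higher number from compound 1 to compound 2 (0.62 log units; beyond the scatter). The change awaiting measurement, (amino in place of hydroxy on a saturated chain carbon bound to a carbonyl carbon), is the same change: both place descriptions read word for word alike, so the only thing that differs is the core it sits on. Within the data shown here, one prior instance exists, so the transfer rests on a single step and on no second example of the same change.

For compound 4 the expected step is a 4.3-fold higher number from compound 3 to compound 4 (0.63 log units; beyond the scatter) in this assay, because on the other core the same change gave a 4.2-fold higher number from compound 1 to compound 2 (0.62 log units; beyond the scatter). The estimate for compound 4 is 170 nM, with a range from 70 nM to 420 nM.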

Compound 4, half-maximal inhibitory concentration: 60 nM
Compound 4: the middle estimate sits 2.8-fold (0.45 log units) above what was measured, outside the stated range (below it).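

On the core of compound 3, amino in place of hydroxy on a saturated chain carbon bound to a carbonyl carbon gives, in this assay, a 1.5-fold higher number from compound 3 to compound 4 (0.18 log units; within the scatter). The change therefore does not carry its size from one core to the other in this series: the same change on two cores in this assay, a 4.2-fold higher number (0.62 log units; beyond the scatter) from compound 1 to compound 2 and a 1.5-fold higher number (0.18 log units; within the scatter) from compound 3 to compound 4, 2.8-fold (0.45 log units) apart, beyond the scatter of two such steps

Two steps show that the core can matter to this change, but they do not show which part of the core is responsible, nor how a third core would respond.

On these data alone, it remains open whether a dimethylamino group, a carboxylic acid or a longer chain such as aminoethyl, on a saturated chain carbon bound to a carbonyl carbon, would also separate the two cores. Also open is which single part of the difference between the two cores accounts for the gap, since that difference is not broken down in the compounds shown.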